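The compounds below may be only part of what the source reports. "The series", "measured", "known", "first", "only" and "open" are said of these compounds alone.

Measured compounds in an assay on isolated protein for inhibition of Amine oxidase [flavin-containing] A (Homo sapiens), read by fluorescence and Amplex Red, with a stated time of 15 min; on this read-out lower numbers stand for stronger inhibition and higher numbers for weaker inhibition:
- compound 1 `C#CCN(CC)Cc1cn(-c2cc(NC(=S)NCC)ncn2)cn1` gives > 50000 nM, a limit of this assay.
- compound 2 `C#CCN(CCC)Cc1cn(-c2cc(NC(=S)NCC)ncn2)cn1` gives > 50000 nM, a limit of this assay.
- compound 3 `C#CCN(Cc1cn(-c2cc(NC(=S)NCC)ncn2)cn1)C(C)=O` gives > 50000 nM, a limit of this assay.

Compound 3 stands at the limit, as do the two other values; no number separates them. The steps a step that the two limits leave unreadable from compound 1 to compound 2, a step that the two limits leave unreadable from compound 1 to compound 3 and a step that the two limits leave unreadable from compound 2 to compound 3 are unreadable in size, since every value sits at the limit of > 50000 nM in this assay, at which 3 of the 3 values shown sit. Compound 4 `C#CCN(Cc1ccccc1)Cc1cn(-c2cc(NC(=S)NCC)ncn2)cn1` differs from compound 3 by benzyl in place of acetyl on an amine nitrogen. Both measured steps on this amine nitrogen leave the value at the limit, so the expected outcome for compound 4 is again a limit or a weak value, with a step of about an at least 1.2-fold lower number from compound 3 to compound 4 (0.09 log units; that floor lies within the scatter). For compound 4 the estimate in this assay is 40000 nM, in the range 5000 nM to 150000 nM.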

Compound 4, half-maximal inhibitory concentration: > 50000 nM
Compound 4: a limit, no number; the forecaster's own chance of this, stated with the estimate: 70%; middle value at least 1.2-fold (0.09 log units) from the limit.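

Going by these compounds alone, compound 4 also stands at a limit, so no step from compound 1, compound 2 or compound 3 to compound 4 can be read: the limit of > 50000 nM in this assay, at which 4 of the 4 values shown sit. The compounds shown leave open whether any group on this amine nitrogen gives a measurable inhibition value.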